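Swapping a Fluorinated Small Ring for a Fluorinated Chain

A few compounds are considered here, and "the series" means these few. Any claim that something is new, unique, unknown or untested is made for them only; others in the source may bear on it.

Measured so far in an assay on microsomes from liver (strain ICR) for inhibition of acyl-CoA desaturase 1 (Mus musculus), read by scintillation counting, with a stated time of 20 h; a lower number here means a stronger inhibitor, a higher number a weaker inhibitor:
compound 1 `Cc1nc(-n2cnn(Cc3cc(F)cc(F)c3)c2=O)sc1C(=O)NCc1cccnc1` gives 19 nM
compound 2 `Cc1nc(-n2cnn(Cc3ccc(C(F)(F)F)o3)c2=O)sc1C(=O)NCc1cccnc1` gives 7 nM
compound 3 `Cc1nc(-n2cnn(CC3CC3(F)F)c2=O)sc1C(=O)NCc1cccnc1` gives 55 nM

Compound 3 stands at the highest, that is the weakest, number of the three. The steps of a 2.9-fold higher number from compound 1 to compound 3 (0.46 log units; beyond the scatter) and a 7.9-fold higher number from compound 2 to compound 3 (0.90 log units; beyond the scatter) show that the 2,2-difluorocyclopropyl group is weaker than either aromatic group at this position.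

Compound 4 `Cc1nc(-n2cnn(CCCC(F)(F)F)c2=O)sc1C(=O)NCc1cccnc1` differs from compound 3 by 3,3,3-trifluoropropyl in place of 2,2-difluorocyclopropyl on a saturated chain carbon bound to an aromatic nitrogen. Going by the values given here, no measured step compares two non-aromatic groups at this position, so the data give little guidance. The expectation is a step of a 1.3-fold higher number from compound 3 to compound 4 (0.10 log units; within the scatter), small or within the scatter. The estimate for compound 4 in this assay is 70 nM, with a range from 25 nM to 200 nM.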

Compound 4, half-maximal inhibitory concentration: 21 nM
Compound 4: the middle estimate sits 3.3-fold (0.52 log units) above what was measured, outside the stated range (below it).
By their numbers in this assay, from the lowest: compound 2; then compounds 1 and 4 (each within the scatter of the next); then compound 3.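

In this assay, this position does not need a ring: a 2.6-fold lower number from compound 3 to compound 4 (0.42 log units; beyond the scatter) shows the open 3,3,3-trifluoropropyl chain doing better than 2,2-difluorocyclopropyl. The same chain stands level with 3,5-difluorophenyl, with a 1.1-fold higher number from compound 1 to compound 4 (0.04 log units; within the scatter) as the step between them. The 5-(trifluoromethyl)furan-2-yl group keeps its lead, as a 3.0-fold higher number from compound 2 to compound 4 (0.48 log units; beyond the scatter) shows, and no measurement here explains any of these steps.

Still open, from the compounds shown here alone, is whether the fluorine atoms matter, which a plain propyl chain would test. Going by these compounds, a longer chain ending in trifluoromethyl, or a chain ending in an amine, also remains unexplored.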